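This account rests on a few compounds, and the source may have more. Where it says the series, first, only, none or still open, it means among the compounds named here.

Going by the values given here, in a functional assay on U-937 cells (Homo sapiens) for cytotoxicity, read by MTT assay, with a stated time of 48 h (a higher number here means a weaker inhibitor, a lower number a stronger inhibitor), compound 3 `Nc1ccccc1Nc1nc(-c2cccc(F)c2)nc2ccc(F)cc12` gives 47300 nM as the only true number among the measured compounds. Compound 1 `COc1ccccc1Nc1nc(-c2cccc(F)c2)nc2ccc(F)cc12` reads > 50000 nM which is a limit of the assay. Compound 2 `Fc1cccc(-c2nc(Nc3ccccc3Br)c3cc(F)ccc3n2)c1` reads > 50000 nM which is also a limit. Among the compounds with values here, compound 4 `Cc1ccccc1Nc1nc(-c2cccc(F)c2)nc2ccc(F)cc12` has methyl in place of amino on an aromatic carbon as its only change from compound 3. The two measured steps that bear on this swap are an at least 1.0-fold lower number from compound 1 to compound 3 (0.02 log units; that floor lies within the scatter) and an at least 1.0-fold lower number from compound 2 to compound 3 (0.02 log units; that floor lies within the scatter) and neither shows a change beyond the scatter. A similar result is expected here in this assay with no step beyond the scatter, though any small drift would be toward a higher number. The expected size is a 1.2-fold higher number from compound 3 to compound 4 (0.07 log units; within the scatter) on this estimate. For compound 4 the estimated value is 55000 nM within an expected range of 30000 nM to 100000 nM and a report as a limit is quite likely.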

Compound 4, half-maximal inhibitory concentration: > 50000 nM
Compound 4: a limit, no number; the forecaster's own chance of this, stated with the estimate: 70%; the middle value does not contradict the limit.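

In this assay, going by these compounds alone, methyl at this place, on an aromatic carbon ortho to a large group, ends at the limit as methoxy and bromo do, which leaves amino as the only group here with a true number. Within the data shown here, the one readable change is small: an at least 1.0-fold higher number from compound 3 to compound 4 (0.02 log units; that floor lies within the scatter). The steps from compound 1 and from compound 2 to compound 4 cannot be read.

On these data alone, how far beyond the limit compound 1, compound 2 and compound 4 truly lie stays open: the limit of > 50000 nM in this assay, at which 3 of the 4 values shown sit. Also open is what a carboxylic acid or a longer chain at this place would give.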